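Trimming a Side Chain Down to a Hydroxy Group

The compounds below may be only part of what the source reports. "The series", "measured", "known", "first", "only" and "open" are said of these compounds alone.

The measure here is a functional assay on the whole organism (Tail, strain ICR) with Mus musculus as the target, in the tail flick test, with a stated time of 120 min, at a dose of 25 umol/kg by the oral route; a lower number here means a weaker effect, a higher number a stronger effect of the compound at the dose given. Compound 1 `NC(=O)CC[C@H](NC(=O)CN(c1ncnc2c1ncn2C1CCCCO1)C1CC1)C(=O)OCc1ccccc1` gives 22.3% there, the highest of the three numbers recorded, though its neighbours are close: compound 2 `O=C(CN(c1nc(Cl)nc2[nH]cnc12)C1CC1)NCC(=O)OCc1ccccc1` gives 21.7% and compound 3 `NCCCC[C@H](NC(=O)CN(c1nc(Cl)nc2[nH]cnc12)C1CC1)C(=O)OCc1ccccc1` gives 16.8%, both within the scatter of compound 1. Within the data shown here, the single step among measured compounds, a number 4.9 percentage points lower from compound 2 to compound 3 (within the scatter), likewise stayed within the scatter.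

Compound 4 `O=C(CN(c1ncnc2c1ncn2C1CCCCO1)C1CC1)N[C@@H](CO)C(=O)OCc1ccccc1` differs from compound 1 by hydroxy in place of carbamoylmethyl on a saturated chain carbon, two bonds along the chain from an amide-type nitrogen and a carbonyl carbon. Among the measured compounds shown here, the only step that bears on it is the one from compound 2 to compound 3, where a side chain on the same kind of carbon was exchanged, and that step was too small to count. The change leading to compound 4 is also an exchange of a side chain at that carbon, so a step beyond the scatter is not expected. The estimate for compound 4 is therefore 20%, with a range from 10% to 32%, which corresponds to an expected step of a number 2.3 percentage points lower from compound 1 to compound 4 (within the scatter).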

Compound 4, a percentage reported as activity, at one dose (the size of the read-out at that dose, not a potency): 29.2%
Estimate against measurement, compound 4: 9.2 percentage points below; the measured number falls inside the stated range.
By their numbers in this assay, from the lowest: compounds 3, 2, 1 and 4 (each within the scatter of the next, the first and the last beyond it).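

In this assay, cutting the side chain from carbamoylmethyl, with its 4 heavy atoms, down to hydroxy, with 1, gives a number 6.9 percentage points higher from compound 1 to compound 4 (within the scatter). So at this saturated chain carbon, on the core of compound 1, the carbamoyl end and the chain that carries it can be lost with no drop in the read-out at this dose, and the step is still too small to count as a gain. This extends what the earlier exchange at the same kind of carbon showed on another core, where adding a 4-aminobutyl group gave a number 4.9 percentage points lower from compound 2 to compound 3 (within the scatter), and no measurement at hand explains either step.

Still open, going by these compounds, is how a carboxylic acid or a plain methyl at this carbon would read on the core of compound 1. A single dose at a single time also leaves open whether hydroxy and carbamoylmethyl would stay this close at other doses or times.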